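A few compounds are considered here, and "the series" means these few. Any claim that something is new, unique, unknown or untested is made for them only; others in the source may bear on it.

Measured compounds:
compound 1, `Cc1nc2ccccc2c(=O)n1/N=C/c1ccc(Oc2ccc(F)cc2)cc1` — 4.21
compound 2, `CCCc1nc2ccccc2c(=O)n1/N=C/c1ccc(Oc2ccc(F)cc2)cc1` — 5.22
compound 3, `O=c1c2ccccc2nc(-c2ccccc2)n1/N=C/c1ccc(Oc2ccccc2)cc1` — 6.13

In a physicochemical assay for lipophilicity, in phosphate buffer, measured as octanol-water partition (on this read-out lower numbers stand for lower lipophilicity and higher numbers for higher lipophilicity), compound 1 stands lowest of the three numbers. The nearest is compound 2, with the step of a number 1.01 log units higher from compound 1 to compound 2 (beyond the scatter). Compound 3 lies furthest away, beyond the scatter; it differs from compound 1 in more than one place, so only its value itself can be read against compound 1.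

Compound 4, `Cc1cc(Oc2ccc(/C=N/n3c(C)nc4ccccc4c3=O)cc2)ccc1Cl`, is not yet measured in this assay. It differs from compound 1 by 4-chloro-3-methylphenyl in place of 4-fluorophenyl on an oxygen on an aromatic ring. Among the measured compounds shown here, the one measured step that bears on it is that from compound 1 to compound 2, where ethyl in place of hydrogen on a saturated chain carbon bound to an aromatic carbon gave a number 1.01 log units higher from compound 1 to compound 2 (beyond the scatter), a large rise from added carbon. The change to compound 4 also adds carbon, by one heavy atom, and exchanges fluorine for chlorine, without any change in donors, acceptors or charge. A rise in this assay beyond the scatter is therefore expected, estimated at a number 0.99 log units higher from compound 1 to compound 4 (beyond the scatter), somewhat smaller because a number 1.01 log units higher from compound 1 to compound 2 (beyond the scatter) rests on a larger added carbon count. For compound 4 the expected value is 5.2, with a range of 4.7 to 5.7.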

Compound 4, partition coefficient: 4.41
Beside the measured number, compound 4's estimate is 0.79 log units above it; the measured number lies below the stated range.
By their numbers in this assay, from the lowest: compounds 1 and 4 (each within the scatter of the next); then compound 2; then compound 3.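

In this assay, 4-chloro-3-methylphenyl in place of 4-fluorophenyl on an oxygen on an aromatic ring gives a number 0.20 log units higher from compound 1 to compound 4 (within the scatter), so this exchange leaves compound 4 indistinguishable from compound 1 on this read-out, even though the entering group holds one more carbon. The other single-place change in the series, ethyl in place of hydrogen on a saturated chain carbon bound to an aromatic carbon, gives a number 1.01 log units higher from compound 1 to compound 2 (beyond the scatter), and the size of that step does not carry over to this position and this change. Nothing available accounts for the contrast between the two steps.

The change at this position exchanges fluorine for chlorine and adds a methyl in one move, so the shown compounds cannot separate the two parts or tell whether each alone would leave the read-out within the scatter of compound 1. Also open, going by these compounds, is how this assay responds at this position to a different kind of group, such as an amine or a carboxylic acid in place of 4-fluorophenyl, and whether the chain step holds with 4-chloro-3-methylphenyl in place.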